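Methoxy for Chloro on Two Related Cores

A few compounds are considered here, and "the series" means these few. Any claim that something is new, unique, unknown or untested is made for them only; others in the source may bear on it.

Three compounds built on closely related cores were examined in an ADME assay on HepG2 cells (Homo sapiens) for cytotoxicity, read by MTT assay, with a stated time of 72 h; a lower number here means that less compound is tolerated, a higher number that more compound is tolerated. Compound 1 `CC(C)Nc1nc2cc(-c3ccc(Cl)cc3)sc2c(=O)[nH]1` carries a chloro on its aryl ring. In this assay compound 1 reaches only a limit, > 15600 nM. Compound 2 `COc1ccc(-c2cc3nc(NC(C)C)[nH]c(=O)c3s2)cc1` shows (methoxy in place of chloro on an aromatic carbon). In this assay compound 2 gives 27100 nM. The step that the limit leaves unreadable from compound 1 to compound 2 cannot be sized because of the limit of > 15600 nM in this assay, at which 1 of the 3 values shown sits. Compound 3 `CC(C)Nc1nc2c(-c3ccc(Cl)cc3)csc2c(=O)[nH]1` has the same atoms as compound 1 joined differently; the difference between the two cores is not broken down here. In this assay compound 3 gives 7100 nM, the lower of the two numbers available, with compound 2 sitting higher by a gap beyond the scatter. Compound 4 `COc1ccc(-c2csc3c(=O)[nH]c(NC(C)C)nc23)cc1` is not yet measured; it differs from compound 3 by methoxy in place of chloro on an aromatic carbon, the same change as that from compound 1 to compound 2. For compound 4 the step is expected to be a 1.7-fold higher number from compound 3 to compound 4 (0.23 log units; within the scatter). That expectation rests on compound 2 giving 27100 nM with the methoxy in place on the other core, while the measured step from compound 1 to compound 2 is not readable. Compound 4 is thus estimated at 12000 nM, within 5000 nM to 30000 nM.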

Compound 4, half-maximal cytotoxic concentration: 27800 nM
Compound 4: the middle estimate sits 2.3-fold (0.36 log units) below what was measured; the measured number falls inside the stated range.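

In this assay methoxy in place of chloro gives a 3.9-fold higher number from compound 3 to compound 4 (0.59 log units; beyond the scatter), so on the core of compound 3 more compound is tolerated with the methoxy present. The same change on the core of compound 1 cannot be sized, because compound 1 stands at a limit and not at a number: the limit of > 15600 nM in this assay, at which 1 of the 4 values shown sits. The series therefore offers one readable step on one core, which shows that the change can move this read-out but not that a step of this size carries over from one core to the other.

The compounds shown leave open how other groups would read in the place of the methoxy, such as an amine, a nitrile or a carboxylic acid. They also leave open whether the step would hold with a longer chain on the amino group of either core, and with groups other than methoxy and chloro on the aromatic ring.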